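Swapping One Diazine for Another on a Sulfonyl Sulfur

This account rests on a few compounds, and the source may have more. Where it says the series, first, only, none or still open, it means among the compounds named here.

Two compounds have so far been tested in a functional assay on HEK293 cells for agonist activity at growth hormone secretagogue receptor type 1 (Homo sapiens), read by HTRF and inositol phosphate accumulation, with a stated time of 90 min, in the presence of a further agent that is not named here; on this read-out higher numbers stand for larger maximal responses and lower numbers for smaller maximal responses:

Compound 1, `Cc1ccc2[nH]c(C(=O)N[C@H]3CN(S(=O)(=O)c4ccccc4)C[C@@H]3C(=O)NCCN(C)C)cc2c1`, gives 93%.
Compound 2, `Cc1ccc2[nH]c(C(=O)N[C@H]3CN(S(=O)(=O)c4ccnnc4)C[C@@H]3C(=O)NCCN(C)C)cc2c1`, gives 89%.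

Compound 2 and compound 1 lie within the scatter of each other, so neither can be placed above the other; the only step shown, a number 4 percentage points lower from compound 1 to compound 2 (within the scatter), comes from putting pyridazin-4-yl in place of phenyl on the sulfonyl sulfur and is within the scatter.

Compound 3, `Cc1ccc2[nH]c(C(=O)N[C@H]3CN(S(=O)(=O)c4cnccn4)C[C@@H]3C(=O)NCCN(C)C)cc2c1`, is the next variation: pyrazin-2-yl in place of pyridazin-4-yl on a sulfonyl sulfur. The two structures hold the same atoms, joined differently. For the measured compounds named here, the one step that bears on this change, a number 4 percentage points lower from compound 1 to compound 2 (within the scatter), exchanged one ring on the same sulfonyl sulfur for another without moving the maximal response beyond the scatter. Compound 3 is therefore expected to show a number 1 percentage points higher from compound 2 to compound 3 (within the scatter), nothing beyond the scatter, and its maximal response is estimated at 90%, within 80% to 100%.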

Compound 3, largest response reached (Emax), in percent of the reference or control that the assay uses: 92%
Compound 3: middle estimate off by 2 percentage points, on the low side; measured number inside the range.
By their numbers in this assay, from the lowest: compounds 2, 3 and 1 (each within the scatter of the next).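

In this assay, the sulfonyl sulfur accepts a second kind of diazine: pyrazin-2-yl in place of pyridazin-4-yl keeps the same atoms, joined differently, and gives a number 3 percentage points higher from compound 2 to compound 3 (within the scatter). The direct comparison with the plain benzene-type ring, pyrazin-2-yl in place of phenyl, gives a number 1 percentage points lower from compound 1 to compound 3 (within the scatter), so all three six-membered aromatic rings tried at this position leave the maximal response within the scatter of one another. No measurement here explains why these rings behave alike.

These compounds leave open whether this tolerance extends beyond six-membered aromatic rings, for example to a small methyl group or a saturated cyclohexyl ring on the sulfonyl sulfur. Maximal response also says nothing about the concentration each compound needs to reach it.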